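Chloro Added to Compound 2: Expected Effect on Inhibition

A few compounds are considered here, and "the series" means these few. Any claim that something is new, unique, unknown or untested is made for them only; others in the source may bear on it.

Measured compounds:
compound 1 `Cc1ccc(C2=NN(C(=O)CN3CCCCC3)C(c3cc(Cl)ccc3O)C2)cc1` — 56200 nM
compound 2 `Cc1ccc(C2=NN(C(=O)Cn3ccnc3)C(c3ccccc3O)C2)cc1` — 41300 nM

In an assay on isolated protein for inhibition of Amine oxidase [flavin-containing] B (Homo sapiens), read by fluorescence, with stated times of 15 min and 20 min (on this read-out lower numbers stand for stronger inhibition and higher numbers for weaker inhibition), compound 1 gives 56200 nM. In this assay compound 2 gives 41300 nM. The two numbers lie within the usual scatter of each other, so on the evidence shown the two compounds cannot be told apart; compound 2 is simply the starting point for the change considered here. Compound 1 and compound 2 differ in two places, so their pair does not isolate any single change.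

Compound 3 `Cc1ccc(C2=NN(C(=O)Cn3ccnc3)C(c3cc(Cl)ccc3O)C2)cc1` has not been measured. It differs from compound 2 in one place: chloro in place of hydrogen on an aromatic carbon. For the measured compounds named here, the same change is present in compound 1, but there it comes together with a different group on the amide, so no clean step for the chloro alone is available. Given that, compound 3 is expected to stay close to compound 2, with a step from compound 2 to compound 3 of a 1.1-fold higher number from compound 2 to compound 3 (0.04 log units; within the scatter), which is no more than the scatter in either direction. Compound 3 is therefore estimated at 45000 nM, with a range from 18000 nM to 110000 nM.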

Compound 3, half-maximal inhibitory concentration: 16100 nM
For compound 3 the middle estimate is 2.8-fold (0.45 log units) above the measured one; measured number below the stated range.
By their numbers in this assay, from the lowest: compound 3; then compounds 2 and 1 (each within the scatter of the next).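

In this assay, for the compounds shown here, chloro in place of hydrogen on an aromatic carbon, para to a hydroxy group, gives a 2.6-fold lower number from compound 2 to compound 3 (0.41 log units; beyond the scatter), the first clean reading of this change and one that shows this position on the aromatic ring can affect inhibition. With the 5-chloro-2-hydroxyphenyl group held constant, 1H-imidazol-1-yl in place of piperidin-1-yl on a saturated chain carbon bound to a carbonyl carbon gives a 3.5-fold lower number from compound 1 to compound 3 (0.54 log units; beyond the scatter), so the group on the amide side chain also affects the read-out, and compound 3 has the lowest number of the three compounds. Nothing shown explains either step.

The compounds shown leave open whether the step belongs to chloro in particular or would also come with fluoro, bromo or methyl at the same place, and whether chloro would give a step of the same size with piperidin-1-yl on the side chain. They also leave open how morpholin-4-yl or dimethylamino on that chain would compare with 1H-imidazol-1-yl.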